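Piperidin-1-yl for pyrrolidin-1-yl: expectation for compound 3

This account rests on a few compounds, and the source may have more. Where it says the series, first, only, none or still open, it means among the compounds named here.

Compound 1 `CN(C)CCC(c1ccc(F)cc1)N1CCCC1` gives 46.6% in an assay on HEK293 cells for inhibition of sodium-dependent dopamine transporter (Homo sapiens), read by scintillation counting, tested at 10 uM (on this read-out lower numbers stand for less inhibition and higher numbers for more inhibition at the one concentration tested (going by the name of the read-out)), the higher of the two numbers shown, although its gap to compound 2 is within the scatter. Compound 2 `CN(C)CCC(c1ccc(C(F)(F)F)cc1)N1CCCC1` gives 37.1%, and the step of a number 9.5 percentage points lower from compound 1 to compound 2 (within the scatter) stays within the scatter. Compound 3 `CN(C)CCC(c1ccc(F)cc1)N1CCCCC1` differs from compound 1 by piperidin-1-yl in place of pyrrolidin-1-yl on a saturated chain carbon bound to an aromatic carbon and a saturated chain carbon. Going by the values given here, no measured step touches this part of the structure, and the one step seen concerns the aromatic substituent only, so no step beyond the scatter is expected in this assay, in either direction. Compound 3 is therefore expected to give 46.6%, within 25% to 65%. The implied step no change at the digits printed from compound 1 to compound 3 (within the scatter) is expected to stay within the scatter.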

Compound 3, a percentage reported as inhibition, at one concentration (the size of the read-out at that concentration, not a potency): 40.1%
Compound 3: the middle estimate sits 6.5 percentage points above what was measured; low and high end bracket the measured number.
By their numbers in this assay, from the lowest: compounds 2, 3 and 1 (each within the scatter of the next).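

This position, on a saturated chain carbon bound to an aromatic carbon and a saturated chain carbon, now has its own reading in this assay: the step is a number 6.5 percentage points lower from compound 1 to compound 3 (within the scatter) for piperidin-1-yl in place of pyrrolidin-1-yl. A six-membered non-aromatic ring here therefore gives no step beyond the scatter. No evidence bears on this result.

On these data alone, whether morpholin-4-yl or an open-chain diethylamino group at this position would give a step beyond the scatter remains open. As far as these compounds go, the effect of a longer chain to the dimethylamino group is equally open.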